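The source may report more compounds than this note shows. Statements on the series, on what has been measured and on what is new or still open speak of the compounds shown alone.

- compound 1 `COC(=O)N1N=C(c2cccc(Cl)c2)CC1c1cc(OC)c(OC)c(OC)c1`: 340 nM
- compound 2 `COC(=O)N1N=C(c2cc(OC)c(OC)c(OC)c2)CC1c1cc(OC)c(OC)c(OC)c1`: 12600 nM

In a functional assay on A549 cells (Homo sapiens) for antiproliferative activity, read by MTT assay, with a stated time of 48 h (on this read-out higher numbers stand for weaker inhibition of growth and lower numbers for stronger inhibition of growth), compound 2 has the higher of the two numbers, at 12600 nM, and the gap to compound 1 at 340 nM lies beyond the scatter. Compound 3 `COC(=O)N1N=C(c2ccc(OC)c(OC)c2)CC1c1cc(OC)c(OC)c(OC)c1` differs from compound 2 by hydrogen in place of methoxy on an aromatic carbon. Among the compounds with values here, no single-place step has been measured, so the expectation rests only on that gap, which shows that much lower numbers are reachable than that of compound 2 at 12600 nM. A moderate move toward stronger inhibition of growth in this assay is expected, with an estimated 3.6-fold lower number from compound 2 to compound 3 (0.56 log units; beyond the scatter). The estimate for compound 3 is 3500 nM, with an expected range of 800 nM to 12000 nM.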

Compound 3, concentration for 50% growth inhibition: 3930 nM
The estimate for compound 3 lay 1.1-fold (0.05 log units) below the measured number; measured number inside the range.
By their numbers in this assay, from the lowest: compound 1; then compound 3; then compound 2.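

In this assay, hydrogen in place of methoxy gives a 3.2-fold lower number from compound 2 to compound 3 (0.51 log units; beyond the scatter) and so moves the number beyond the scatter at this single position. The step of a 12-fold higher number from compound 1 to compound 3 (1.06 log units; beyond the scatter) is still large, so this one change does not close the gap to compound 1. Nothing measured here gives a reason for either step.

As far as these compounds go, whether a hydroxyl group or an amine in place of this methoxy would move the number further remains open. So does the effect of an ethyl ester in place of the methyl ester on the shared core.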